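Cyclopropyl for 1-methoxyethyl at the clearance limit

This account rests on a few compounds, and the source may have more. Where it says the series, first, only, none or still open, it means among the compounds named here.

In an ADME assay on microsomes from liver (Rattus norvegicus) for metabolic stability (a higher number here means faster removal of the compound, a lower number slower removal), compound 1 `CC(C)c1c(NC(=O)Nc2ccnc(C(F)(F)F)c2)cnc2cc(Cl)nn12` gives < 25 mL.min-1.g-1 as a limit of the assay and not a number. Compound 2 `CO[C@H](C)c1c(NC(=O)Nc2cnc(-n3nccn3)c(Cl)c2)cnc2cc(Cl)nn12` likewise gives < 25 mL.min-1.g-1 as a limit, so no number is known for it. Compound 3 `O=C(Nc1cnc(-n2nccn2)c(Cl)c1)Nc1cnc2cc(Cl)nn2c1C1CC1` differs from compound 2 by cyclopropyl in place of 1-methoxyethyl on an aromatic carbon and is still unmeasured. Within the data shown here, no measured pair shows this change, and no shift beyond the scatter is expected in either direction in this assay. The estimated step is a step that the limit leaves unreadable from compound 2 to compound 3 and remains an expectation. For compound 3 the expected value is 22 mL.min-1.g-1 with an estimated range of 12 mL.min-1.g-1 to 45 mL.min-1.g-1 in this measurement.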

Compound 3, intrinsic clearance in microsomes: 50.4 mL.min-1.g-1
Estimate against measurement, compound 3: 2.3-fold (0.36 log units) below; the measured number lies above the stated range.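

In this assay, cyclopropyl in place of 1-methoxyethyl next to the ring nitrogen gives an at least 2.0-fold higher number from compound 2 to compound 3 (0.30 log units; that floor lies within the scatter). This is the first sign that this position can carry the read-out off the limit, since compound 3 is the only compound shown with a number. Only a floor can be read for the step, and its true size stays hidden: the limit of < 25 mL.min-1.g-1 in this assay, at which 2 of the 3 values shown sit.

The compounds shown leave open whether losing the oxygen or gaining the three-membered ring drives the step. They also leave open how an ethyl or a methoxymethyl group would read at this position.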